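This account rests on a few compounds, and the source may have more. Where it says the series, first, only, none or still open, it means among the compounds named here.

Values in a functional assay on A549 cells (Homo sapiens) for inhibition, read by CCK-8 assay, with a stated time of 72 h, tested at 2 uM; a higher number here means more inhibition of growth at the concentration tested, a lower number less inhibition of growth:
- compound 1 `CCc1ccc(SCc2ccc(/C=C/C(=O)Nc3ccccc3N)cc2)cc1`: 60.7%
- compound 2 `Nc1ccccc1NC(=O)c1ccc(CSCCc2ccccc2)cc1`: 44.9%
- compound 3 `Nc1ccccc1NC(=O)c1ccc(CSc2ccc(F)cc2)cc1`: 43.4%
- compound 4 `CC(C)(C)c1ccc(SCc2ccc(/C=C/C(=O)Nc3ccccc3N)cc2)cc1`: not yet measured

Compound 1 gives the highest number of the three, and both compound 2 and compound 3 lie beyond the scatter from it. Compound 4 keeps the core of compound 1 and changes one group: tert-butyl in place of ethyl on an aromatic carbon. This places tert-butyl in place of ethyl on an aromatic carbon, para to a large group. For the measured compounds named here, no measured step covers this exchange. Going by the values given here, one measured step bears on it, and only loosely: a number 1.5 percentage points lower from compound 2 to compound 3 (within the scatter), for 4-fluorophenyl in place of phenethyl on a sulfur, so no shift beyond the scatter is expected in this assay. That step sits in a different part of the series, which leaves the expectation uncertain. The expected change is small, estimated as a number 2.7 percentage points lower from compound 1 to compound 4 (within the scatter). Compound 4 is estimated at 58%, with an expected range of 43% to 72%.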

Compound 4, percent growth inhibition at one concentration: 71.5%
Beside the measured number, compound 4's estimate is 13.5 percentage points below it, within the range that was stated.
By their numbers in this assay, from the lowest: compounds 3 and 2 (each within the scatter of the next); then compound 1; then compound 4.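

In this assay, for the compounds shown here, the change from 4-ethylphenyl to 4-(tert-butyl)phenyl gives a number 10.8 percentage points higher from compound 1 to compound 4 (beyond the scatter) and is the first step that lies beyond the scatter. Going by these compounds alone, the only earlier step, a number 1.5 percentage points lower from compound 2 to compound 3 (within the scatter), concerned a group on a sulfur and stayed within the scatter, whereas this aromatic carbon, para to a large group, responds to the exchange of one alkyl group for another in the core of compound 1. No measurement among those given explains this gain.

With only ethyl and tert-butyl shown at this carbon, it remains open how a longer chain, an amine or a carboxylic acid there would read in this assay as a number. On these data alone, it also remains open whether 4-(tert-butyl)phenyl in place of 4-fluorophenyl would give a comparable step on the core of compound 3.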